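This account rests on a few compounds, and the source may have more. Where it says the series, first, only, none or still open, it means among the compounds named here.

Measured compounds:
Compound 1, `OC(c1ccc(Cl)cc1)(c1cccnc1)c1ccccc1Cl`: 61300 nM
Compound 2, `Cc1ccccc1C(O)(c1ccc(Cl)cc1)c1cccnc1`: 82000 nM
Compound 3, `Cc1ccc(C(O)(c2ccc(OC(C)C)cc2)c2cccnc2)c(F)c1`: 62600 nM

In an ADME assay on L6 cells (Rattus norvegicus) for cytotoxicity, read by resazurin assay, with a stated time of 72 h (a lower number here means a stronger inhibitor, a higher number a weaker inhibitor), compound 1 gives 61300 nM, compound 2 gives 82000 nM and compound 3 gives 62600 nM; all three lie within the scatter of one another. Compound 2 and compound 1 differ in one place only: chloro in place of methyl on an aromatic carbon. That change made a 1.3-fold lower number from compound 2 to compound 1 (0.13 log units; within the scatter). The difference between the core of compound 2 and the core of compound 3 is not broken down here.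

Compound 4, `CC(C)Oc1ccc(C(O)(c2cccnc2)c2ccc(Cl)cc2F)cc1`, has not yet been measured. It differs from compound 3 by chloro in place of methyl on an aromatic carbon. This is the same kind of change as that from compound 2 to compound 1, but the surroundings differ: in compound 1 the chloro sits ortho to a large group, whereas in compound 4 it sits meta to a fluoro group and para to a large group. Resting on the small step seen in a 1.3-fold lower number from compound 2 to compound 1 (0.13 log units; within the scatter), compound 4 is expected to land close to compound 3, with an expected step of a 1.1-fold lower number from compound 3 to compound 4 (0.06 log units; within the scatter). The estimate for compound 4 in this assay is 55000 nM, with a range from 28000 nM to 105000 nM.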

Compound 4, half-maximal inhibitory concentration: 56000 nM
Compound 4: middle estimate off by 1.0-fold (0.01 log units), on the low side; measured number inside the range.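

In this assay, chloro in place of methyl on an aromatic carbon gives a 1.1-fold lower number from compound 3 to compound 4 (0.05 log units; within the scatter), so the change has now been read on two cores. The two readings agree: the same change on two cores in this assay, a 1.3-fold lower number (0.13 log units; within the scatter) from compound 2 to compound 1 and a 1.1-fold lower number (0.05 log units; within the scatter) from compound 3 to compound 4, 1.2-fold (0.08 log units) apart, within the scatter of two such steps This shows that, on these two cores, the change carried from one to the other without a step beyond the scatter on either; it does not show that the change has any real effect in this assay, as both steps are small enough to be scatter, and two pairs say nothing about how it would read on a further core.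

The compounds shown leave open whether any other group in the place of the chloro or methyl, such as an amine, a carboxylic acid or a longer chain, would move the number beyond the scatter. They also leave open whether such a group would read the same on the core of compound 2 and on the core of compound 3.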